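The source may hold more compounds than are shown below. What is called first, only, known or untested is meant among the compounds shown, and "the series" means these compounds.

Compound 1 `Cc1ccc(-c2c(C)c(-c3ccc(C)c(C)c3)c(C(OC(C)(C)C)C(=O)O)c(C)c2NC(=O)Nc2ccccc2)cc1C` was tested in an ADME assay on MT4 cells (Homo sapiens) for cytotoxicity, read by MTT assay, with a stated time of 4 days (on this read-out higher numbers stand for lower toxicity in this test and lower numbers for higher toxicity in this test), where compound 1 gives 8000 nM. Within the data shown here, this is the only outright number recorded here; the other result is a limit of the assay rather than a number. Compound 2 `Cc1ccc(-c2c(C)c(-c3ccccc3)c(C(OC(C)(C)C)C(=O)O)c(C)c2NS(C)(=O)=O)cc1C` gives > 50000 nM in this assay, which is such a limit (the limit of > 50000 nM in this assay, at which 1 of the 2 values shown sits). Compound 3 `CNc1c(C)c(C(OC(C)(C)C)C(=O)O)c(-c2ccc(C)c(C)c2)c(C)c1-c1ccc(C)c(C)c1` has not yet been measured; it differs from compound 1 by methyl in place of phenylcarbamoyl on a nitrogen on an aromatic ring. Among the measured compounds shown here, no measured pair shares this change, so its effect is uncertain. The expected step is a 1.9-fold higher number from compound 1 to compound 3 (0.27 log units; within the scatter), a modest move toward lower toxicity, close to the usual scatter. Compound 3 is estimated at 15000 nM, between 5000 nM and 50000 nM.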

Compound 3, half-maximal cytotoxic concentration: 8800 nM
The estimate for compound 3 lay 1.7-fold (0.23 log units) above the measured number; measured number inside the range.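

Among these compounds, this is the first measured pair for methyl in place of phenylcarbamoyl on a nitrogen on an aromatic ring, and in this assay the two compounds read alike (a 1.1-fold higher number from compound 1 to compound 3 (0.04 log units; within the scatter)). The group that leaves has 9 heavy atoms and a six-membered aromatic ring, while the one that enters has a single carbon, yet the reading of compound 3 does not stand apart from that of compound 1.

Going by these compounds, whether a free amine or a longer chain on this nitrogen would read the same stays open. Nothing measured here says why these two groups read alike.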